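Ring stereocentre change from compound 3 to compound 4

This account rests on a few compounds, and the source may have more. Where it says the series, first, only, none or still open, it means among the compounds named here.

In a physicochemical assay for metabolic stability, read by HPLC, in phosphate buffer, with a stated time of 12 h, at pH 6.8 (a lower number here means that the compound disappears faster, a higher number that the compound lasts longer), compound 1 (`O=C(O)[C@H](CO)NC(=O)[C@H]1C[C@H](O)CN1`) gives > 12 h as a limit and not a number. Compound 2 (`O=C(O)[C@@H](CO)NC(=O)[C@H]1C[C@@H](O)CN1`) gives > 12 h as a limit and not a number. Compound 3 (`O=C(O)[C@@H](CO)NC(=O)[C@H]1C[C@H](O)CN1`) gives > 12 h as a limit and not a number. Compound 3 therefore has no number of its own and stands with the whole series at the limit of > 12 h in this assay, at which 3 of the 3 values shown sit, in these notes.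

The change to compound 4 (`O=C(N[C@H](CO)C(=O)O)[C@@H]1C[C@H](O)CN1`) is the two compounds have the same atoms and bonds and differ only in configuration as drawn: 1 of 3 stereo elements differ; a stereocentre at a saturated ring carbon is drawn R in compound 3 and S in compound 4 in which a stereocentre at a saturated ring carbon is drawn R in compound 3 and S in compound 4.

The closest measured precedent also changes a ring stereocentre: a step that the two limits leave unreadable from compound 2 to compound 3 gives no size to carry over. The other two, a step that the two limits leave unreadable from compound 1 to compound 3 and a step that the two limits leave unreadable from compound 1 to compound 2, are equally without size.

No step beyond the scatter is expected in this assay and no direction is favoured, so the expected size is a step that the limit leaves unreadable from compound 3 to compound 4 in these notes. Compound 4 is estimated at 16 h with an expected range from 12 h to 30 h in this assay's terms, and a further limit is the likeliest report.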

Compound 4, half-life: > 12 h
Compound 4 was reported as a limit (the forecaster's own chance of this, stated with the estimate: 90%); the middle value lies beyond the limit too.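

In this assay compound 4 gives > 12 h, a limit and not a number. Its steps from compound 1, compound 2 and compound 3 therefore cannot be read. The compounds shown leave open the actual half-life of each compound and whether configuration changes it at all.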